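Closing two methoxy groups into a dioxin ring

The source may hold more compounds than are shown below. What is called first, only, known or untested is meant among the compounds shown, and "the series" means these compounds.

Measured compounds:
Compound 1 `CNc1nc(Nc2ccc(C)c([N+](=O)[O-])c2)ncc1C(=O)Nc1cc(NC(=O)c2cccc(OC)c2)ccc1C`: 480 nM
Compound 2 `CNc1nc(Nc2ccc(C)c([N+](=O)[O-])c2)ncc1C(=O)Nc1cc(NC(=O)c2ccc(OC)c(OC)c2)ccc1C`: 680 nM

Both compounds share one core and differ only at the benzoyl end. In a functional assay on K562 cells (Homo sapiens) for antiproliferative activity, read by CellTiter-Glo and CCK-8 assay, with a stated time of 72 h (on this read-out higher numbers stand for weaker inhibition of growth and lower numbers for stronger inhibition of growth), compound 1 gives 480 nM, and compound 2 gives 680 nM. Among the measured compounds shown here, the one measured step, a 1.4-fold higher number from compound 1 to compound 2 (0.15 log units; within the scatter), shows that adding a methoxy group did not move the read-out beyond the usual scatter. Compound 2 carries the higher of the two numbers, but its distance from compound 1 is within that scatter, so the two cannot be ranked.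

Compound 3 `CNc1nc(Nc2ccc(C)c([N+](=O)[O-])c2)ncc1C(=O)Nc1cc(NC(=O)c2ccc3c(c2)OCCO3)ccc1C` has not yet been measured. Its change from compound 2 is 2,3-dihydro-1,4-benzodioxin-6-yl in place of 3,4-dimethoxyphenyl on a carbonyl carbon; the two methoxy groups are, in effect, joined into a 2,3-dihydro-1,4-benzodioxin-6-yl ring. For the measured compounds named here, no measured step covers this ring closure; the only step available, a 1.4-fold higher number from compound 1 to compound 2 (0.15 log units; within the scatter), concerned the methoxy groups themselves and stayed within the scatter. On that thin basis no shift beyond the scatter is expected, so for compound 3 the estimated step is a 1.1-fold lower number from compound 2 to compound 3 (0.04 log units; within the scatter). Compound 3 is therefore expected at about 620 nM, with a range from 300 nM to 1400 nM.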

Compound 3, concentration for 50% growth inhibition: 320 nM
For compound 3 the middle estimate is 1.9-fold (0.29 log units) above the measured one; the measured number falls inside the stated range.
By their numbers in this assay, from the lowest: compounds 3, 1 and 2 (each within the scatter of the next, the first and the last beyond it).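

In this assay, among the compounds shown here, closing the two methoxy groups of the 3,4-dimethoxyphenyl group into the 2,3-dihydro-1,4-benzodioxin-6-yl ring gives a 2.1-fold lower number from compound 2 to compound 3 (0.33 log units; beyond the scatter) and so provides the first step at this benzoyl end to clear the usual scatter, if only modestly. Both groups have the same counts of heavy atoms, hydrogen-bond donors and hydrogen-bond acceptors, so the closed ring is the structural difference between them, yet the comparison with the 3-methoxyphenyl group of compound 1 gives a 1.5-fold lower number from compound 1 to compound 3 (0.18 log units; within the scatter) and leaves those two compounds unranked. The data shown offer no explanation of how the closed ring differs in effect from the two open methoxy groups.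

From the compounds shown here alone, the size of the ring remains open: it is unknown whether a bridge of one carbon between the two oxygens, or a longer chain of three carbons, would hold the gain seen against compound 2. It is also unknown whether an amine or a carboxylic acid on the closed ring would be tolerated at this end of the molecule.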